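A few compounds are considered here, and "the series" means these few. Any claim that something is new, unique, unknown or untested is made for them only; others in the source may bear on it.

Compound 2, `COc1ccc(S(=O)(=O)NC(=O)Nc2ccc(Cl)cc2)s1`, gives 93% in a functional assay on the whole organism (6C3HED cells, Mus musculus) for inhibition, at a dose of 150 mg/kg by the oral route (on this read-out lower numbers stand for less inhibition and higher numbers for more inhibition at the one dose given (going by the name of the read-out)), the highest of the two numbers at hand; its nearest neighbour is compound 1, `O=C(Nc1ccc(Cl)cc1)NS(=O)(=O)c1cccs1`, which in this assay gives 16%. For the measured compounds named here, the only measured step, a number 77 percentage points higher from compound 1 to compound 2 (beyond the scatter), shows that a group on the aromatic carbon next to the ring sulfur makes a large difference here. Compound 3, `CC(C)(C)c1ccc(S(=O)(=O)NC(=O)Nc2ccc(Cl)cc2)s1`, differs from compound 2 by tert-butyl in place of methoxy on an aromatic carbon. A group stays at that carbon, so compound 3 is expected to keep much of the inhibition, with a modest expected drop of a number 21 percentage points lower from compound 2 to compound 3 (beyond the scatter) and an estimated 72%, between 35% and 98%.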

Compound 3, a percentage reported as inhibition, in the whole organism at one dose (the size of the read-out at that dose, not a potency): 7%
For compound 3 the middle estimate is 65 percentage points above the measured one; measured number below the stated range.
By their numbers in this assay, from the lowest: compounds 3 and 1 (each within the scatter of the next); then compound 2.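

At this position, next to the ring sulfur, having a group is not enough; which group stands there matters: tert-butyl in place of methoxy brings a number 86 percentage points lower from compound 2 to compound 3 (beyond the scatter). Tert-butyl in place of hydrogen brings a number 9 percentage points lower from compound 1 to compound 3 (within the scatter), so of the three compounds only the one with methoxy at this carbon shows high inhibition. Nothing at hand accounts for this difference between the two groups. The compounds shown leave open how ethoxy, methyl or an amine at this carbon would read, and so whether the high number belongs to methoxy alone.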